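A few compounds are considered here, and "the series" means these few. Any claim that something is new, unique, unknown or untested is made for them only; others in the source may bear on it.

Measured compounds:
compound 1 `O=C(N/N=C/c1ccccc1)Nc1ccc(Oc2ccnc3[nH]ccc23)c(F)c1`, 640 nM
compound 2 `O=C(N/N=C/c1ccccc1)Nc1ccc(Oc2ccnc3[nH]ccc23)cc1`, 750 nM
compound 3 `O=C(N/N=C/c1cccn1CCCN1CCCCC1)Nc1ccc(Oc2ccnc3[nH]ccc23)c(F)c1`, 2840 nM

All three were tested in a functional assay on HepG2 cells (Homo sapiens) for antiproliferative activity, read by MTT assay, with a stated time of 72 h; on this read-out lower numbers stand for stronger inhibition and higher numbers for weaker inhibition. Among the three numbers, compound 2 holds the second highest place; its nearest neighbour is compound 1, and the step of a 1.2-fold higher number from compound 1 to compound 2 (0.07 log units; within the scatter) lies within the scatter, so the two cannot be ordered. Compound 3 stands furthest from compound 2, with a number beyond the scatter of it.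

The step now followed leads from compound 2 to compound 4 `CN(C)CCCn1cccc1/C=N/NC(=O)Nc1ccc(Oc2ccnc3[nH]ccc23)cc1`, through the change (1-(3-(dimethylamino)propyl)-1H-pyrrol-2-yl in place of phenyl on a carbon with a double bond to nitrogen). No measured step covers this change directly: the only listed step, from compound 1 to compound 2, concerns the fluoro and is within the scatter. What the numbers of compound 1 and compound 3 show is that replacing phenyl with a substituted pyrrol-2-yl went together with a clearly higher number in this assay. The expected step of a 3.3-fold higher number from compound 2 to compound 4 (0.52 log units; beyond the scatter) is therefore upward, beyond the scatter. Compound 4 is estimated at 2500 nM, in the range 1000 nM to 6500 nM.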

Compound 4, half-maximal inhibitory concentration: 4190 nM
Compound 4: the middle estimate sits 1.7-fold (0.22 log units) below what was measured; low and high end bracket the measured number.
By their numbers in this assay, from the lowest: compounds 1 and 2 (each within the scatter of the next); then compounds 3 and 4 (each within the scatter of the next).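

Among these compounds, the change of phenyl to 1-(3-(dimethylamino)propyl)-1H-pyrrol-2-yl on a carbon with a double bond to nitrogen now has a measured step of its own, whereas the only earlier step concerned the fluoro. In this assay the change gives a 5.6-fold higher number from compound 2 to compound 4 (0.75 log units; beyond the scatter), so this position does respond to the exchange, and the number rises beyond the scatter with the phenyl gone and the substituted pyrrole in its place. No measurement at hand accounts for this rise.

Among the compounds shown here, the single step changes the ring and adds the chain together, so it remains open how much of the rise belongs to each. An unsubstituted pyrrol-2-yl, a 1-methyl-1H-pyrrol-2-yl or a longer chain ending in a morpholine would be needed to tell these parts apart.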